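This account rests on a few compounds, and the source may have more. Where it says the series, first, only, none or still open, it means among the compounds named here.

In a functional assay on A-431 cells (Homo sapiens) for inhibition, with a stated time of 72 h (on this read-out lower numbers stand for stronger inhibition and higher numbers for weaker inhibition), compound 1 `CCN(CC)Cc1cc(Cl)c2cccnc2c1O` gives 9330 nM and compound 2 `Oc1c(CN2CCCC2)cc(Cl)c2cccnc12` gives 7410 nM, so compound 2 stands level with compound 1. Among the measured compounds shown here, the only measured step, a 1.3-fold lower number from compound 1 to compound 2 (0.10 log units; within the scatter), concerns the amine and not the chloro position. Compound 3 `COCc1cc(CN2CCCC2)c(O)c2ncccc12` has methoxymethyl in place of chloro on an aromatic carbon, para to a hydroxy group (methoxymethyl in place of chloro on an aromatic carbon). For the measured compounds named here, no measured step covers this change, so no step beyond the scatter is expected in this assay, with wide uncertainty. The expected change is a 1.2-fold higher number from compound 2 to compound 3 (0.08 log units; within the scatter). Compound 3 is estimated at 9000 nM, within an expected range of 3500 nM to 23000 nM.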

Compound 3, half-maximal inhibitory concentration: 52500 nM
Compound 3: middle estimate off by 5.8-fold (0.77 log units), on the low side; the whole stated range lies below it.
By their numbers in this assay, from the lowest: compounds 2 and 1 (each within the scatter of the next); then compound 3.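

At the aromatic carbon para to a hydroxy group, the group matters in this assay: methoxymethyl in place of chloro gives a 7.1-fold higher number from compound 2 to compound 3 (0.85 log units; beyond the scatter) and so weakens inhibition. Among the compounds shown, this is the only step beyond the scatter, since the amine change stayed within it. Nothing available bears on why the number rises.

From the compounds shown here alone, it remains open whether fluoro, methyl or hydroxymethyl at this position would stay level with compound 2. Also open, going by these compounds, is whether methoxymethyl gives a similar step alongside diethylamino.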